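Lengthening the Chain of Compound 1 Toward Compound 3

The source may report more compounds than this note shows. Statements on the series, on what has been measured and on what is new or still open speak of the compounds shown alone.

Compound 1 `CCOC(=O)[C@@H](N)CCC(=O)NCCSC(C)=O` and compound 2 `CCCOC(=O)[C@@H](N)CCC(=O)NCCSC(=O)C(C)(C)C` stand level in an ADME assay on isolated protein for metabolic stability, with Cocaine esterase (Homo sapiens) as the target; a higher number here means that the compound lasts longer, a lower number that the compound disappears faster: compound 1 gives 0.167 h and compound 2 gives 0.167 h, with no difference beyond the scatter. Compound 3 `CCCCOC(=O)[C@@H](N)CCC(=O)NCCSC(C)=O` differs from compound 1 in one place: ethyl in place of hydrogen on a saturated chain carbon, two bonds along the chain from an oxygen next to a carbonyl group. For the measured compounds named here, compound 2 already carries a longer chain along with other differences and shows no shift, though no single step between measured compounds is known. The step from compound 1 is therefore expected to stay within the scatter, no change at the digits printed from compound 1 to compound 3 (within the scatter). Compound 3 is estimated at 0.167 h, between 0.08 h and 0.35 h.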

Compound 3, half-life in the Cocaine esterase assay: 0.167 h
Compound 3: middle estimate and measured number agree at the digits printed, and the stated range covers the measured number.
By their numbers in the Cocaine esterase assay, from the lowest: compounds 1, 2 and 3 (each within the scatter of the next).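

For the compounds shown here, in the Cocaine esterase assay, ethyl in place of hydrogen at this position gives no change at the digits printed from compound 1 to compound 3 (within the scatter), the first reading of this change on its own. In a physicochemical assay for lipophilicity, measured as octanol-water partition, at pH 2 (on this read-out higher numbers stand for higher lipophilicity and lower numbers for lower lipophilicity), compound 1 gives 0.11 and compound 3 gives 0.43, so the same change gives a number 0.32 log units higher from compound 1 to compound 3 (beyond the scatter). The partition coefficient therefore separates the two compounds, while their half-lives stand level. The compounds shown leave open whether a longer chain, an amine or a carboxylic acid at this position would shift the half-life.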